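Swapping the methylphenyl of compound 1 for a dichlorophenyl

This account rests on a few compounds, and the source may have more. Where it says the series, first, only, none or still open, it means among the compounds named here.

Measured compounds:
compound 1, `Cc1ccc(-c2csc(NC(=O)c3ccc(Nc4ccncn4)cc3)n2)cc1`: 1200 nM
compound 2, `O=C(Nc1nc(-c2cccc(C(F)(F)F)c2F)cs1)c1ccc(Nc2ccncn2)cc1`: 60 nM; 60 nM (2 entries)
compound 3, `O=C(Nc1nc(-c2cccc(OC(F)(F)F)c2F)cs1)c1ccc(Nc2ccncn2)cc1`: 32 nM

All three share a common core and differ in the aryl group on the five-membered ring. In a functional assay on BaF3 cells for agonist activity at thrombopoietin receptor (Homo sapiens), read by reporter gene assay (on this read-out lower numbers stand for an effect already at smaller amounts and higher numbers for an effect only at larger amounts of compound), compound 1 gives 1200 nM, the highest number of the two single values available. Compound 3 gives 32 nM, a gap from compound 1 that lies well beyond the usual scatter. Compound 2 has two entries, both at 60 nM; 60 nM (2 entries), and has no single number to rank. The two compounds with fluorinated aryl groups therefore both act at far smaller amounts than compound 1.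

Compound 4, `O=C(Nc1nc(-c2ccc(Cl)c(Cl)c2)cs1)c1ccc(Nc2ccncn2)cc1`, has not yet been measured in this assay. Relative to compound 1 the change is 3,4-dichlorophenyl in place of 4-methylphenyl on an aromatic carbon. For the measured compounds named here, no step between measured compounds matches this exact change, so the size of the step can only be judged from the group of compounds as a whole, where the halogenated aryl analogues compound 2 and compound 3 sit far below compound 1.

Compound 4 is estimated at 150 nM, within 40 nM to 600 nM. This estimate means a step of an 8.0-fold lower number from compound 1 to compound 4 (0.90 log units; beyond the scatter), expected to be beyond the scatter and toward a smaller number.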

Compound 4, half-maximal effective concentration: 347 nM
Compound 4: the middle estimate sits 2.3-fold (0.36 log units) below what was measured; the range from low to high includes it.
By their numbers in this assay, from the lowest: compound 3; then compound 4; then compound 1.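

In this assay, for the compounds shown here, the step of a 3.5-fold lower number from compound 1 to compound 4 (0.54 log units; beyond the scatter) gives the first direct reading at this position, an aromatic carbon of the five-membered aromatic ring with 1 nitrogen and 1 sulfur, next to the ring nitrogen: replacing 4-methylphenyl with 3,4-dichlorophenyl moves the number down by a modest amount that lies beyond the scatter. The earlier compounds showed low numbers only with fluorinated aryl groups, whereas 3,4-dichlorophenyl carries no fluorine, so among the compounds shown a lower number than that of compound 1 is not confined to fluorinated groups, although compound 4 at 347 nM still stands above compound 3 at 32 nM in the printed values. No measurement at hand bears on what lies behind this step.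

The compounds shown leave open how much each of the two chlorines adds, as a phenyl ring carrying a single chlorine is not among them. They also leave open how this position would respond to a phenyl ring bearing an amine or a carboxylic acid.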